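Swapping a Chlorine for a Methyl on the Aryl Ring

This account rests on a few compounds, and the source may have more. Where it says the series, first, only, none or still open, it means among the compounds named here.

Of the compounds shown here, three built on one shared core have been tested in an ADME assay on Vero cells (Chlorocebus sabaeus) for cytotoxicity, read by neutral red uptake, tested at 787 ug/mL; a lower number here means a stronger effect, a higher number a weaker effect of the compound at the concentration tested. Compound 1 `O=C1CSC(c2c(Cl)cccc2Cl)N1CCN1CCCCC1` gives 11%. Compound 2 `O=C1CSC(c2cccc(Cl)c2)N1CCN1CCCCC1` gives 31%. Compound 3 `O=C1CSC(c2ccccc2[N+](=O)[O-])N1CCN1CCCCC1` gives 100%. On these numbers compound 2 stands second highest of the three: its nearest neighbour is compound 1, whose number is lower by more than the usual scatter, and its furthest is compound 3, whose number is far higher, also beyond the scatter.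

Compound 4 `Cc1ccc(C2SCC(=O)N2CCN2CCCCC2)cc1` has not yet been measured. Its structure differs from compound 2 in one place: 4-methylphenyl in place of 3-chlorophenyl on a saturated ring carbon. Among the compounds with values here, no measured pair shows exactly this change, so the size of the step is uncertain. Compound 1 and compound 2 sit at the low end and compound 3 at the top; compound 4 carries neither chlorine nor the nitro group. A modest move upward in this assay is expected, possibly no larger than the scatter, giving a number 14 percentage points higher from compound 2 to compound 4 (beyond the scatter). For compound 4 the estimate in this assay is 45%, expected to fall between 15% and 90%.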

Compound 4, a percentage reported as activity, at one concentration (the size of the read-out at that concentration, not a potency): 17%
Compound 4: middle estimate off by 28 percentage points, on the high side; the range from low to high includes it.
By their numbers in this assay, from the lowest: compounds 1 and 4 (each within the scatter of the next); then compound 2; then compound 3.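

In this assay, the change on this saturated ring carbon gives a number 14 percentage points lower from compound 2 to compound 4 (beyond the scatter). A chlorine on the aryl group is therefore not required for a low number here, since compound 4 carries none and gives 17%. This single step alters two things at once, the group on the aryl ring and where that group sits, so it cannot show which of the two matters, and nothing on hand explains the direction of the step.

Going by these compounds, it remains open whether 3-methylphenyl or 4-chlorophenyl, each changing only one of those two things, would read closer to compound 2 or to compound 4. Also open, on these data alone, is how a plain phenyl group, or a methoxy group or an amine on the aryl ring, would read at this carbon.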